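Compound 2 loses its 4-nitrophenyl group

This account rests on a few compounds, and the source may have more. Where it says the series, first, only, none or still open, it means among the compounds named here.

In a physicochemical assay for lipophilicity, at pH 7.4, tested at 10 mM (a higher number here means a more lipophilic compound, a lower number a more polar compound), compound 2 `Cc1cc(COc2cc(C)nn2-c2ccc([N+](=O)[O-])cc2)n(-c2ccccc2)n1` reads 3.7 and stands highest of the two measured compounds. Compound 1 `Cc1cc(SSc2cc(C)nn2-c2ccccc2)n(-c2ccccc2)n1` reads 3.2 there, a gap beyond the usual scatter. The compound still to be measured, compound 3 `Cc1cc(OCc2cc(C)nn2-c2ccccc2)[nH]n1`, has hydrogen in place of 4-nitrophenyl on an aromatic nitrogen of a five-membered aromatic ring with 2 nitrogen. For the measured compounds named here, no measured pair shows a change of this kind, so the data offer no direct guide to its size. A fall in this assay well beyond the scatter is nonetheless expected, and the estimated step runs a number 1.30 log units lower from compound 2 to compound 3 (beyond the scatter) on that scale. Compound 3 is estimated at 2.4 with an expected range (1.8 to 3).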

Compound 3, distribution coefficient: 2.9
Beside the measured number, compound 3's estimate is 0.50 log units below it; low and high end bracket the measured number.
By their numbers in this assay, from the lowest: compounds 3 and 1 (each within the scatter of the next); then compound 2.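

For the compounds shown here, at this aromatic nitrogen, hydrogen in place of 4-nitrophenyl gives a number 0.80 log units lower from compound 2 to compound 3 (beyond the scatter) in this assay and so supplies the first measured step in the set, where the earlier compounds offered only two values with no single change between them. The position therefore registers this change, although the step is modest for the departure of a group of 9 heavy atoms that includes a six-membered aromatic ring of carbon only. Nothing at hand explains the size of this step.

The compounds shown leave open how the step divides between the ring and its nitro group, a question that a plain phenyl or a methyl on this nitrogen would address. Going by these compounds, how an amine or a carboxylic acid at the same place would read on this scale also remains open.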